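The compounds below may be only part of what the source reports. "The series", "measured", "known", "first", "only" and "open" are said of these compounds alone.

In a functional assay on MCF7 cells (Homo sapiens) for antiproliferative activity, read by sulforhodamine B assay, with a stated time of 72 h (a lower number here means a stronger inhibitor, a higher number a weaker inhibitor), compound 1 `Cc1ccc(S(=O)(=O)Nc2cc(SC(C)C(=O)N[C@@H](CC(C)C)B(O)O)c(O)c3ccccc23)cc1` gives 8610 nM, compound 2 `CC(C)C[C@H](NC(=O)C(C)Sc1cc(NS(=O)(=O)c2ccc(Cl)cc2)c2ccccc2c1O)B(O)O` gives 10100 nM; 10700 nM (2 entries) and compound 3 `CC(C)C[C@H](NC(=O)C(C)Sc1cc(NS(=O)(=O)c2cccs2)c2ccccc2c1O)B(O)O` gives 14700 nM. Within the data shown here, compound 3 therefore stands within the scatter of compound 1, and the series so far is confined to a narrow band of values.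

Compound 4 `CC(=O)Nc1ccc(S(=O)(=O)Nc2cc(SC(C)C(=O)N[C@@H](CC(C)C)B(O)O)c(O)c3ccccc23)cc1` keeps the shared core and differs from compound 3 in one place: 4-acetamidophenyl in place of thiophen-2-yl on a sulfonyl sulfur. The change puts 4-acetamidophenyl in place of thiophen-2-yl on a sulfonyl sulfur.

Among the measured compounds shown here, the only measured step at this place, a 1.7-fold higher number from compound 1 to compound 3 (0.23 log units; within the scatter), replaces 4-methylphenyl with thiophen-2-yl and stays within the scatter. For the measured compounds named here, no measured step covers 4-acetamidophenyl, so this one step is thin support. On that basis, no step beyond the scatter is expected in this assay, and no direction is favoured.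

The expected change is a 1.2-fold lower number from compound 3 to compound 4 (0.09 log units; within the scatter), which would be within the scatter. The estimate for compound 4 is 12000 nM, with an expected range of 5000 nM to 28000 nM.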

Compound 4, half-maximal inhibitory concentration: 8910 nM
Estimate against measurement, compound 4: 1.3-fold (0.13 log units) above; measured number inside the range.
By their numbers in this assay, from the lowest: compounds 1, 4 and 3 (each within the scatter of the next).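

Replacing thiophen-2-yl with 4-acetamidophenyl on the sulfonyl sulfur gives a 1.6-fold lower number from compound 3 to compound 4 (0.22 log units; within the scatter) in this assay, so a group of 10 heavy atoms with a hydrogen-bond donor takes the place of one of 5 heavy atoms without a step beyond the scatter. Acetamido in place of methyl on an aromatic carbon gives a 1.0-fold higher number from compound 1 to compound 4 (0.01 log units; within the scatter), which is the first direct comparison of two substituents on the phenyl ring at this place and shows no separation between them. The flat reading of these steps sits alongside close agreement between repeat entries: the several entries of compound 2 in this assay, 10100 nM; 10700 nM (2 entries)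

On these data alone, the effect of an open-chain alkyl group on the sulfonyl sulfur, or of a carboxylic acid or an amine on the phenyl ring, remains open. As far as these compounds go, whether any group at this place can produce a step beyond the scatter also remains open.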